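Urea series: aryl swap on the urea nitrogen

A few compounds are considered here, and "the series" means these few. Any claim that something is new, unique, unknown or untested is made for them only; others in the source may bear on it.

Three ureas on a shared core have been run in an assay on CHO cells for displacement of a labelled ligand from adenosine receptor A1 (Homo sapiens), tested at 10 uM; a higher number here means more inhibition at the concentration tested (going by the name of the read-out), a lower number less inhibition. Compound 1 `COc1ccc(OC)c(NC(=O)Nc2nn(-c3ccccc3)c(=O)c3ccccc23)c1` gives 0%, compound 2 `O=C(NCc1ccccc1)Nc1nn(-c2ccccc2)c(=O)c2ccccc12` gives 20%, and compound 3 `COc1ccc(NC(=O)Nc2nn(-c3ccccc3)c(=O)c3ccccc23)c(OC)c1` gives 29%. Compound 3 holds the highest number of the three; its gap to compound 2 lies within the scatter, while the rise a number 29 percentage points higher from compound 1 to compound 3 (beyond the scatter) lies beyond it. The step of a number 20 percentage points higher from compound 1 to compound 2 (beyond the scatter) also lies beyond the scatter, and a number 9 percentage points higher from compound 2 to compound 3 (within the scatter) does not.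

Compound 4 `Cc1ccccc1NC(=O)Nc1nn(-c2ccccc2)c(=O)c2ccccc12` follows from compound 3 by the change (2-methylphenyl in place of 2,4-dimethoxyphenyl on an amide-type nitrogen). Among the measured compounds shown here, no measured step removes both methoxy groups, so the nearest guide is the aryl-pattern step a number 29 percentage points higher from compound 1 to compound 3 (beyond the scatter), which shows that changing substituents on this aryl ring can move this assay by a modest amount in either direction. A modest drop is therefore expected for compound 4, estimated as a number 12 percentage points lower from compound 3 to compound 4 (beyond the scatter), landing near the level of compound 2. The expected value for compound 4 in this assay is 17%, with a range from 0% to 38%.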

Compound 4, a percentage reported as inhibition, at one concentration (the size of the read-out at that concentration, not a potency): 20%
For compound 4 the middle estimate is 3 percentage points below the measured one; low and high end bracket the measured number.
By their numbers in this assay, from the lowest: compound 1; then compounds 2, 4 and 3 (each within the scatter of the next).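

In this assay, 2-methylphenyl in place of 2,4-dimethoxyphenyl on the amide-type nitrogen gives a number 9 percentage points lower from compound 3 to compound 4 (within the scatter), so an aryl group without oxygen holds the level of the dimethoxy compound. Against the benzyl urea, the same group gives no change at the digits printed from compound 2 to compound 4 (within the scatter), while against the 2,5-dimethoxyphenyl urea it gives a number 20 percentage points higher from compound 1 to compound 4 (beyond the scatter), which leaves compound 1 as the only one of the four set apart from all the others by more than the scatter. No supporting data explain why compound 1 stands apart.

Still open, from the compounds shown here alone, is whether an unsubstituted phenyl, a chloro group or a carboxylic acid on this aryl ring, or a phenethyl chain on this nitrogen, would move the number beyond the scatter of compound 3. A single-concentration read-out also leaves the potency of these ureas open.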